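The source may report more compounds than this note shows. Statements on the series, on what has been measured and on what is new or still open speak of the compounds shown alone.

In a functional assay on the whole organism with Rattus norvegicus as the target, in the maximal electroshock model (on this read-out higher numbers stand for an effect only at larger amounts of compound and lower numbers for an effect already at smaller amounts), compound 1 `c1ccc(Cn2ccc3c(NC4CC4)ncnc32)cc1` gives 36 mg/kg. Compound 2 `Nc1ncnc2c1cnn2Cc1ccccc1` has only a limit, > 25 mg/kg, and no number. Within the data shown here, its true position is therefore open, and no measured step gives a size to lean on.

Compound 3 `Nc1ncnc2c1cnn2Cc1ccccc1F` differs from compound 2 in one place: fluoro in place of hydrogen on an aromatic carbon, ortho to a large group. Among the measured compounds shown here, no measured pair shows what this replacement does in this assay, so the expectation is loose and the margins are wide. A move towards smaller doses, somewhat beyond the usual scatter, is expected, though no real change cannot be ruled out. The expected move is an at least 2.0-fold lower number from compound 2 to compound 3 (0.31 log units; beyond the scatter). Compound 3 is estimated at 12 mg/kg, with an expected range of 4 mg/kg to 35 mg/kg.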

Compound 3, dose for half-maximal effect: 8 mg/kg
For compound 3 the middle estimate is 1.5-fold (0.18 log units) above the measured one; the range from low to high includes it.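

In this assay, among these compounds, fluoro in place of hydrogen on an aromatic carbon, ortho to a large group, is the first single-place change with a readable direction, towards smaller doses: an at least 3.1-fold lower number from compound 2 to compound 3 (0.49 log units; beyond the scatter). As far as these compounds go, compound 2 has a limit and not a number, so this step fixes only a minimum size, and the full size stays unknown: the limit of > 25 mg/kg in this assay, at which 1 of the 3 values shown sits. The step does show that a single fluorine on this aromatic ring, with no added ring, hydrogen-bond donor, hydrogen-bond acceptor or net charge, is enough to move the read-out beyond the scatter.

From the compounds shown here alone, whether the move is specific to fluoro, or would also appear with chloro, methoxy or an amine at this place, stays open. Also open, going by these compounds, is whether the same replacement would act alike on the core of compound 1.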